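The compounds below may be only part of what the source reports. "The series", "measured", "known", "first", "only" and "open" are said of these compounds alone.

Measured in a functional assay on HEK293 cells for agonist activity at Free fatty acid receptor 1 (Homo sapiens), read by fluorescence and calcium flux, with a stated time of 10 min; a higher number here means a larger maximal response, a lower number a smaller maximal response:
compound 1 `O=C(O)CCc1ccc(NCC2COc3ccc(Cl)cc3O2)cc1F`: 69%
compound 2 `Cn1cncc1C(CC(=O)O)c1ccc(OCC2COc3ccc(Cl)cc3O2)cc1`: 62%
compound 3 `CC#C[C@@H](CC(=O)O)c1ccc(OC[C@H]2COc3ccc(Br)cc3O2)cc1`: 69%

Compound 3 stands level with compound 1 at the digits shown, and compound 2 sits apart from it only by a margin within the scatter, so the three largest-response values lie together. Going by the values given here, no pair among the measured compounds differs in a single place, so no step is known in this assay. Compound 4 `CC#C[C@@H](CC(=O)O)c1ccc(OC[C@H]2COc3ccc(C(=O)N4CCOCC4)cc3O2)cc1` differs from compound 3 in one place: (morpholin-4-yl)carbonyl in place of bromo on an aromatic carbon. With nothing comparable among the measured compounds to rest on, the step of a number 4 percentage points lower from compound 3 to compound 4 (within the scatter) is expected to be none beyond the scatter, in either direction. Compound 4 is estimated at 65%, with a range from 48% to 82%.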

Compound 4, largest response reached (Emax), in percent of the reference or control that the assay uses: 33%
Beside the measured number, compound 4's estimate is 32 percentage points above it; the whole stated range lies above it.
By their numbers in this assay, from the lowest: compound 4; then compounds 2, 1 and 3 (each within the scatter of the next).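

In this assay, going by these compounds alone, the change from bromo to (morpholin-4-yl)carbonyl gives a number 36 percentage points lower from compound 3 to compound 4 (beyond the scatter) and provides the first single-place step. The maximal response therefore depends on the group at this aromatic carbon, which earlier compounds could not show without a single-place pair. No supporting data on the origin of the loss are available. As far as these compounds go, whether the ring of the morpholine, its oxygen or the carbonyl matters remains open. A nitrile or a (piperidin-1-yl)carbonyl at this position would help to separate these.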